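A few compounds are considered here, and "the series" means these few. Any claim that something is new, unique, unknown or untested is made for them only; others in the source may bear on it.

Three ureas built on the same core have been tested in an ADME assay on the whole organism with Oryza sativa as the target, tested at 0.1 uM; a lower number here means a stronger effect, a higher number a weaker effect of the compound at the concentration tested. Compound 1 `Cc1ccccc1NC(=O)N[C@H](C)c1ccccc1` gives 100% in this assay. Compound 2 `Cc1ccccc1NC(=O)N[C@@H](C)c1ccccc1` gives 100% in this assay. Between them, no change at the digits printed from compound 1 to compound 2 (within the scatter), a result that sits beside the fact that compounds 1 and 2 differ only in the configuration as drawn and so says that the drawn configuration alone leaves the read-out where it was. Compound 3 `CCc1cccc(NC(=O)N[C@H](C)c2ccccc2)c1` carries an ethyl group on the other aromatic ring and gives 97% in this assay. Compound 2 therefore stands level with compound 1 at the digits given, and compound 3 lies within the scatter of both, so the three numbers are not told apart by this kind of measurement.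

Compound 4 `CC(C)c1ccccc1NC(=O)N[C@@H](C)c1ccccc1` is the next structure. Compared with compound 2, the change is isopropyl in place of methyl on an aromatic carbon. Within the data shown here, only one measured step exists here, and it concerns configuration rather than the size of a group, so no measured step bears directly on this change. The values of compound 2 and compound 3 show that a small alkyl group on an aromatic ring, in either of the two positions seen, leaves the read-out near the top of the scale. Compound 4 is expected to do the same, with a step of a number 2 percentage points lower from compound 2 to compound 4 (within the scatter) that should stay within the scatter. The estimate for compound 4 is 98%, within a range from 88% to 100%.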

Compound 4, a percentage reported as activity, at one concentration (the size of the read-out at that concentration, not a potency): 99%
Compound 4: the middle estimate sits 1 percentage points below what was measured; the measured number falls inside the stated range.
By their numbers in this assay, from the lowest: compounds 3, 4, 1 and 2 (each within the scatter of the next).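

In this assay, putting isopropyl in place of methyl on an aromatic carbon, ortho to a large group, gives a number 1 percentage points lower from compound 2 to compound 4 (within the scatter). Among these compounds, this is the first measured step that concerns the size of a group rather than drawn configuration, and it shows that this position can hold a group of 3 heavy atoms instead of 1 heavy atom with no difference that this kind of measurement can detect. Among the compounds shown here, the result describes only this one swap, and nothing measured here offers a reason for it.

All the compounds shown are hydrocarbon-substituted ureas that read near the top of the scale, so it remains open whether any group on this aromatic carbon can bring the number down clearly, for example an amine, a carboxylic acid or a longer chain. For the compounds shown here, also open is whether isopropyl would behave the same way in the opposite drawn configuration, since the only configuration step available was read with methyl at this position.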